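A few compounds are considered here, and "the series" means these few. Any claim that something is new, unique, unknown or untested is made for them only; others in the source may bear on it.

Measured so far in an ADME assay on Vero cells (Chlorocebus sabaeus) for cytotoxicity, read by MTT assay, with a stated time of 72 h (on this read-out lower numbers stand for higher toxicity in this test and higher numbers for lower toxicity in this test), are these compounds:

Compound 1 `COc1ccc(-c2cc(-c3ccc(C4NC(=O)c5ccccc5N4)cc3)nc(N)n2)cc1` gives 124000 nM
Compound 2 `Nc1nc(-c2ccc(Cl)cc2)cc(-c2ccc(C3NC(=O)c4ccccc4N3)cc2)n1` gives 323000 nM
Compound 3 `Nc1nc(-c2ccc(C3NC(=O)c4ccccc4N3)cc2)cc(-c2ccccc2Cl)n1` gives "not determined" (no result reported)

Compound 3 has no place on this scale, since no result was reported for it and it offers no number to start from. Compound 4 `Nc1nc(-c2ccc(Br)cc2)cc(-c2ccc(C3NC(=O)c4ccccc4N3)cc2)n1` has not yet been measured. Going from compound 3 to it brings 4-bromophenyl in place of 2-chlorophenyl on an aromatic carbon and so puts a 4-bromophenyl in place of a 2-chlorophenyl on an aromatic carbon.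

Among the measured compounds shown here, only one measured step is available, and it does not start from compound 3. It is a 2.6-fold higher number from compound 1 to compound 2 (0.42 log units; beyond the scatter) and it is modest, with chloro in place of methoxy on an aromatic carbon. For the measured compounds named here, with no number for compound 3, no step to compound 4 can be sized, so none is predicted in either direction. The better guide is compound 2 at 323000 nM. Compound 2 differs from compound 4 only in holding chlorine instead of bromine. A gap from compound 2 no larger than that one modest step is expected, and its direction is open. In this assay compound 4 is expected at about 280000 nM (estimated range 120000 nM to 600000 nM).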

Compound 4, half-maximal cytotoxic concentration: > 400000 nM
Compound 4: only a limit was reported; the forecaster's own chance of this, stated with the estimate: 15%; at least 1.4-fold (0.15 log units) between middle value and limit.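

In this assay compound 4 reaches > 400000 nM, which is a limit of the assay and not a number. In place of methoxy, bromo gives an at least 3.2-fold higher number from compound 1 to compound 4 (0.50 log units; beyond the scatter), and chloro gives a 2.6-fold higher number from compound 1 to compound 2 (0.42 log units; beyond the scatter), so both halogens shown on this phenyl ring move the read-out towards lower toxicity in this test, and no compound with a value goes against that. Bromo in place of chloro gives an at least 1.2-fold higher number from compound 2 to compound 4 (0.09 log units; that floor lies within the scatter), and the true size of this gap cannot be stated, since the result stops at a limit: the limit of > 400000 nM in this assay, at which 1 of the 4 values shown sits.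

The step from compound 3 to compound 4 cannot be read, as compound 3 has no result, so nothing here shows whether moving a halogen around the phenyl ring matters in this test. Also open, on these data alone, is how an amine, a carboxylic acid or a longer chain in place of the halogen on this phenyl ring would read in this assay.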